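The source may report more compounds than this note shows. Statements on the series, on what has been measured and on what is new or still open speak of the compounds shown alone.

Three hydrazone compounds built on a shared core have been tested for their ability to slow the growth of a breast cancer cell line, and a fourth awaits its turn. Compound 1 `COc1ccc2c(c1)c(/C=N\NC(=O)c1c[nH]c3ccc(Br)cc13)cn2Cc1ccc(Cl)cc1` gives 29100 nM in a functional assay on MCF7 cells (Homo sapiens) for cytotoxicity; on this read-out lower numbers stand for stronger inhibition and higher numbers for weaker inhibition. Compound 2 `O=C(N/N=C\c1cn(Cc2ccc(Cl)cc2)c2ccc(Br)cc12)c1c[nH]c2ccccc12` gives 3200 nM in this assay, and compound 3 `O=C(N/N=C\c1cn(Cc2ccc(Cl)cc2)c2cc(F)ccc12)c1c[nH]c2ccccc12` gives 6000 nM. Among these numbers compound 3 stands second highest: its value and that of compound 2 lie within the usual scatter of each other, while compound 1 sits clearly higher, beyond the scatter. Since each pair of these compounds differs in more than one place, no single change can be read from them.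

Compound 4 `Cn1cc(C(=O)N/N=C\c2cn(Cc3ccc(Cl)cc3)c3cc(F)ccc23)c2ccccc21` differs from compound 3 in exactly one place: methyl in place of hydrogen on an aromatic nitrogen. The hydrogen on that aromatic nitrogen is the only point changed. Nothing in the three measured compounds shows what this exchange does, so the expectation rests on the change alone: the step from compound 3 to compound 4 is expected to be small, a 1.5-fold higher number from compound 3 to compound 4 (0.18 log units; within the scatter), toward a weaker result but possibly within the scatter. Compound 4 is estimated at 9000 nM, with a range from 3000 nM to 27000 nM.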

Compound 4, half-maximal inhibitory concentration: 90600 nM
Beside the measured number, compound 4's estimate is 10-fold (1.00 log units) below it, outside the stated range (above it).
By their numbers in this assay, from the lowest: compounds 2 and 3 (each within the scatter of the next); then compound 1; then compound 4.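

In this assay, replacing 1H-indol-3-yl with 1-methyl-1H-indol-3-yl gives a 15-fold higher number from compound 3 to compound 4 (1.18 log units; beyond the scatter), a large step beyond the scatter. The earlier compounds shown here all carry hydrogen on this aromatic nitrogen, so they could not show that this position is so sensitive: adding a single carbon here is enough to weaken the result markedly. Nothing available explains why this small exchange has so large an effect.

As far as these compounds go, with only hydrogen and methyl seen on this nitrogen, it remains open whether any group there would weaken the result, or whether a longer chain such as ethyl or propyl, or an acetyl group, would behave differently. It is also unknown whether the same exchange would have a similar effect on compound 2, which differs from compound 3 elsewhere on the shared core.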